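The compounds below may be only part of what the source reports. "The series", "measured", "known", "first", "only" and "open" are said of these compounds alone.

Measured so far:
Compound 1 `CN1CCN(c2ccc(Nc3ncc(Cl)c(NCc4ccco4)n3)nc2)CC1` in a functional assay on MDA-MB-231 cells (Homo sapiens) for inhibition, read by CCK-8 assay, with a stated time of 48 h; on this read-out higher numbers stand for weaker inhibition of growth and lower numbers for stronger inhibition of growth: compound 1 gives 11000 nM
Compound 2 `CCc1ccc(Nc2nc(Nc3ccc(N4CCN(C)CC4)cn3)ncc2Cl)cc1` in this assay: compound 2 gives 5560 nM

In this assay, going by the values given here, compound 2 holds the lowest of the two numbers, with compound 1 as its only neighbour; the step of a 2.0-fold lower number from compound 1 to compound 2 (0.30 log units; within the scatter) lies within the scatter, so the two compounds cannot be ordered on these numbers.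

Compound 3 `COc1cccc(Nc2nc(Nc3ccc(N4CCN(C)CC4)cn3)ncc2Cl)c1` is not yet measured. It differs from compound 2 in one place: 3-methoxyphenyl in place of 4-ethylphenyl on a nitrogen on an aromatic ring. Among the compounds with values here, the only measured step, a 2.0-fold lower number from compound 1 to compound 2 (0.30 log units; within the scatter), exchanges a different group on the same nitrogen on an aromatic ring and is itself within the scatter; no measured step swaps one aryl group for another at that place, so there is nothing that points in either direction. The expected step of a 1.0-fold lower number from compound 2 to compound 3 (0.00 log units; within the scatter) is therefore none beyond the scatter. Compound 3 is estimated at 5500 nM, with a range from 2000 nM to 15000 nM.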

Compound 3, concentration for 50% growth inhibition: 8510 nM
Compound 3: middle estimate off by 1.5-fold (0.19 log units), on the low side, and the stated range covers the measured number.
By their numbers in this assay, from the lowest: compounds 2, 3 and 1 (each within the scatter of the next).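

In this assay, going by these compounds alone, the step of a 1.5-fold higher number from compound 2 to compound 3 (0.18 log units; within the scatter) is the first exchange of one aryl group for another on this nitrogen, and it lies within the scatter, so 3-methoxyphenyl and 4-ethylphenyl cannot be told apart here, even though only the entering group counts a hydrogen-bond acceptor. The step of a 1.3-fold lower number from compound 1 to compound 3 (0.11 log units; within the scatter) also lies within the scatter, so a second aryl group likewise cannot be separated from (furan-2-yl)methyl at this place. Nothing available explains these results.

From the compounds shown here alone, all three compounds remain within the scatter of one another, so it is still open whether any exchange on this nitrogen can move the number beyond it. Also open, going by these compounds, is whether a carboxylic acid or an amine on the aryl ring, or a cyclohexyl group in its place, would give a step beyond the scatter.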